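This account rests on a few compounds, and the source may have more. Where it says the series, first, only, none or still open, it means among the compounds named here.

Of the compounds shown here, three have been measured in a functional assay on the whole organism for inhibition, with Nicotiana tabacum as the target; on this read-out lower numbers stand for stronger inhibition and higher numbers for weaker inhibition. Compound 1 `COc1ccc(Nc2[nH]c(C)nc3nccc2-3)cc1` gives 661000000 nM, and compound 2 `CCOc1ccc(Nc2[nH]c(C)nc3nccc2-3)cc1` gives 347000000 nM. Within the data shown here, the single one-place step among the measured compounds, a 1.9-fold lower number from compound 1 to compound 2 (0.28 log units; within the scatter), is therefore of a size that the assay cannot separate from repeat measurement. Compound 3 `Cc1nc(NC2CCCC2)c2cc[nH]c2n1` gives 72400000 nM, the lowest number of the three; its distance to compound 2 and its larger distance to compound 1 both lie beyond the usual scatter, so compound 3 stands as the strongest inhibitor of the set.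

Compound 4 `Cc1nc(NCCCO)c2cc[nH]c2n1` arises from compound 3 through one change: 3-hydroxypropyl in place of cyclopentyl on a nitrogen on an aromatic ring. Among the measured compounds shown here, no measured step bears on this change. For the measured compounds named here, the only step known, from compound 1 to compound 2, concerns a different part of the molecule and was within the scatter, so it gives no guidance on size or direction here. What the data do show is that compound 3, carrying a saturated substituent on the aromatic nitrogen, stands well below compounds 1 and 2. Replacing the ring with an open chain is a larger change than anything measured, and an estimate must stay cautious.

Compound 4 is accordingly expected to give 150000000 nM, with a range from 40000000 nM to 600000000 nM. This estimate implies an expected step of a 2.1-fold higher number from compound 3 to compound 4 (0.32 log units; beyond the scatter), leaning toward a weaker inhibition than compound 3 but with wide uncertainty.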

Compound 4, half-maximal inhibitory concentration: 17800000 nM
The estimate for compound 4 lay 8.4-fold (0.93 log units) above the measured number; the whole stated range lies above it.
By their numbers in this assay, from the lowest: compound 4; then compound 3; then compounds 2 and 1 (each within the scatter of the next).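

In this assay the nitrogen on an aromatic ring accepts an open chain in place of a ring, with a 4.1-fold lower number from compound 3 to compound 4 (0.61 log units; beyond the scatter) when 3-hydroxypropyl replaces cyclopentyl. The five-membered ring of compound 3 is therefore not needed at this position to reach a low number, and the number falls further without it. The group that enters carries a hydrogen-bond donor and a hydrogen-bond acceptor where cyclopentyl carries neither, so this position also accepts an oxygen-bearing chain, though that reading rests on this single pair; nothing shown gives a reason for the step.

The compounds shown do not separate the loss of the ring from the arrival of the hydroxyl, a question that a plain propyl chain or a hydroxycyclopentyl group at the same nitrogen could settle. They also leave open how the number would move with a longer chain carrying the hydroxyl, or with an amine or a carboxylic acid in place of the hydroxyl.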